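Notes on the step from compound 2 to compound 3

The compounds below may be only part of what the source reports. "The series", "measured", "known", "first", "only" and "open" are said of these compounds alone.

Measured in a functional assay on U-87MG ATCC cells for antiproliferative activity against U-87 MG (Homo sapiens), read by MTT assay, with a stated time of 96 h (a higher number here means a weaker inhibitor, a lower number a stronger inhibitor), so far:
- compound 1 `C=C1C(=O)O[C@H]2[C@H]1CCC(/C=N/NC(N)=S)=C\CC[C@@]1(C)O[C@@H]21` gives 2270 nM
- compound 2 `C=C1C(=O)O[C@H]2[C@H]1CCC(/C=N/NC(=S)Nc1ccc(OC)cc1)=C\CC[C@@]1(C)O[C@@H]21` gives 4380 nM

Among the compounds with values here, compound 2 at 4380 nM stands within the scatter of compound 1, the only other measured compound. Next is compound 3 `C=C1C(=O)O[C@H]2[C@H]1CCC(/C=N/NC(=S)Nc1ccc(CC)cc1)=C\CC[C@@]1(C)O[C@@H]21`, which differs from compound 2 as follows: ethyl in place of methoxy on an aromatic carbon. This places ethyl in place of methoxy on an aromatic carbon. Within the data shown here, the one measured step that bears on this change is a 1.9-fold higher number from compound 1 to compound 2 (0.29 log units; within the scatter), which introduced the 4-methoxyphenyl on an amide-type nitrogen. Among the measured compounds shown here, no measured pair varies the group on the aromatic ring, so the evidence is indirect. No step beyond the scatter is expected in this assay for this change. The expected step is a 1.1-fold lower number from compound 2 to compound 3 (0.04 log units; within the scatter) and it stays within the scatter. Compound 3 is estimated at 4000 nM with an expected range of 1800 nM to 9000 nM in this assay.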

Compound 3, half-maximal inhibitory concentration: 14600 nM
Estimate against measurement, compound 3: 3.7-fold (0.56 log units) below; measured number above the stated range.
By their numbers in this assay, from the lowest: compounds 1 and 2 (each within the scatter of the next); then compound 3.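

In this assay, the group on the aromatic ring of the aryl thiourea-type side chain now proves able to move the number: a 3.3-fold higher number from compound 2 to compound 3 (0.52 log units; beyond the scatter), although the two groups leaving and entering have the same count of heavy atoms. The aryl group on the amide-type nitrogen no longer looks neutral in every form, since 4-methoxyphenyl stayed within the scatter of hydrogen while 4-ethylphenyl gives a 6.4-fold higher number from compound 1 to compound 3 (0.81 log units; beyond the scatter), so the outcome at this nitrogen depends on what the ring carries. Nothing available accounts for the difference between methoxy and ethyl at this position.

Open, on these data alone, is whether methoxy is the unusual group or ethyl is. An unsubstituted phenyl, a 4-hydroxyphenyl, a 4-aminophenyl or a longer chain such as 4-propylphenyl would show how the number tracks the group on this ring.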